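Cyclopropylamino in Place of Hydroxyethylamino on a Shared Core

The source may hold more compounds than are shown below. What is called first, only, known or untested is meant among the compounds shown, and "the series" means these compounds.

Of the compounds shown here, three with a common core have been measured in an assay on isolated protein for binding affinity to adenosine receptor A1 (Bos taurus); on this read-out higher numbers stand for weaker inhibition and lower numbers for stronger inhibition. Compound 1 `OCCNc1nc(-c2ccccc2)nc2c1nnn2Cc1ccccc1` gives 38000000 nM and stands lowest of the three, with compound 2 nearest and compound 3 furthest. Compound 2 `OCCNc1nc(-c2ccccc2)nc2c1nnn2Cc1ccccc1F` gives 54000000 nM in this assay, and compound 3 `OCCNc1nc(-c2ccccc2)nc2c1nnn2Cc1ccccc1Cl` gives 116000000 nM. The step of a 1.4-fold higher number from compound 1 to compound 2 (0.15 log units; within the scatter) is small, whereas a 3.1-fold higher number from compound 1 to compound 3 (0.48 log units; beyond the scatter) and a 2.1-fold higher number from compound 2 to compound 3 (0.33 log units; beyond the scatter) are both modest.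

Compound 4 `c1ccc(Cn2nnc3c(NC4CC4)nc(-c4ccccc4)nc32)cc1` has not yet been measured in this assay. It differs from compound 1 as follows: cyclopropyl in place of 2-hydroxyethyl on a nitrogen on an aromatic ring. All three measured steps concern only a substituent on the benzyl aromatic ring; none of them touches the group on the ring nitrogen that changes here, so none bears on this change. Within the data shown here, with no measured step to lean on, the account can only say that the direction of any shift is unknown and that a step within the scatter or of modest size in either direction is as plausible as any other.

On that basis compound 4 is expected to give 38000000 nM in this assay, within a range from 8000000 nM to 180000000 nM, which corresponds to an expected step of no change at the digits printed from compound 1 to compound 4 (within the scatter).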

Compound 4, inhibition constant: 11000000 nM
Compound 4: the middle estimate sits 3.5-fold (0.54 log units) above what was measured; the measured number falls inside the stated range.
By their numbers in this assay, from the lowest: compound 4; then compounds 1 and 2 (each within the scatter of the next); then compound 3.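

Among these compounds, the nitrogen on an aromatic ring proves to be a place where this assay responds to a change: cyclopropyl in place of 2-hydroxyethyl gives a 3.5-fold lower number from compound 1 to compound 4 (0.54 log units; beyond the scatter) and so moves the number beyond the scatter, in the direction of stronger inhibition, whereas all the earlier steps lay on the benzyl aromatic ring. The result also shows that the hydrogen-bond donor and acceptor counted on 2-hydroxyethyl are not needed to reach a lower number at this place, since cyclopropyl carries neither and compound 4 still stands below compound 1. No measurement is at hand that explains this shift, so the result stands without a stated cause.

Among the compounds shown here, the single step replaces the open chain with a three-membered ring and removes the hydroxyl at the same time, so it cannot separate the two, and an ethyl or 2-methoxyethyl group would be needed to tell them apart, with cyclobutyl showing whether a larger ring behaves alike. As far as these compounds go, it also remains open whether the fluoro and chloro steps on the benzyl aromatic ring would carry over to the cyclopropylamino series.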